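Fluoro for Chloro on the Benzylsulfanyl Arm

A few compounds are considered here, and "the series" means these few. Any claim that something is new, unique, unknown or untested is made for them only; others in the source may bear on it.

Compound 1 `CC1=C(C(=O)Nc2ccc(Br)cc2)C(c2ccc(Cl)cc2Cl)N=C(SCc2ccc(Cl)cc2)N1` and compound 2 `CC1=C(C(=O)Nc2ccc(Br)cc2)C(c2ccc(Cl)cc2Cl)N=C(SCc2ccc(F)cc2)N1` share one core, while compound 3 `CC1=C(C(=O)Nc2ccc([N+](=O)[O-])cc2)C(c2cccc([N+](=O)[O-])c2)N=C(SCc2ccc(Cl)cc2)N1` rests on another; the difference between the two cores is not broken down here. In a functional assay on the whole organism (artery, strain albino) with Rattus norvegicus as the target, with a stated time of 360 min, at a dose of 10 mg/kg by the oral route (a lower number here means less inhibition, a higher number more inhibition at the dose given (going by the name of the read-out)), compound 1 gives 39.7% and compound 2 gives 40.7%. The change between them is fluoro in place of chloro on an aromatic carbon, and it made a number 1 percentage points higher from compound 1 to compound 2 (within the scatter). In this assay compound 3 gives 33%. Compound 4 `CC1=C(C(=O)Nc2ccc([N+](=O)[O-])cc2)C(c2cccc([N+](=O)[O-])c2)N=C(SCc2ccc(F)cc2)N1` has not yet been measured; it differs from compound 3 by fluoro in place of chloro on an aromatic carbon, the same change at the same place as between compound 1 and compound 2. The step from compound 3 to compound 4 is expected to be a number 1 percentage points higher from compound 3 to compound 4 (within the scatter) in this assay. That expectation rests on compound 2, whose step a number 1 percentage points higher from compound 1 to compound 2 (within the scatter) stayed within the scatter. Compound 4 is therefore estimated at 34%, with a likely range from 24% to 44%.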

Compound 4, a percentage reported as inhibition, in the whole organism at one dose (the size of the read-out at that dose, not a potency): 36.1%
Estimate against measurement, compound 4: 2.1 percentage points below; measured number inside the range.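

In this assay, fluoro in place of chloro on the core of compound 3 gave a number 3.1 percentage points higher from compound 3 to compound 4 (within the scatter). Set beside the same swap on the core of compound 1, the two steps do not differ: the same change on two cores in this assay, a number 1 percentage points higher (within the scatter) from compound 1 to compound 2 and a number 3.1 percentage points higher (within the scatter) from compound 3 to compound 4, 2.1 percentage points apart, within the scatter of two such steps This shows that, on these two cores, the swap from (4-chlorobenzyl)sulfanyl to (4-fluorobenzyl)sulfanyl left the read-out within the scatter both times, but it does not show that fluoro offers any gain, nor that the agreement would hold on a third core.

From the compounds shown here alone, only chloro and fluoro appear at this place, so how a methoxy group, an amine or a carboxylic acid would read there remains open. Going by these compounds, a longer chain in place of the benzyl group also remains open.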